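The compounds below may be only part of what the source reports. "The series", "measured", "known", "first", "only" and "open" are said of these compounds alone.

Of the compounds shown here, two from this set have been tested in a functional assay on MCF7 cells (Homo sapiens) for cytotoxicity, read by MTT assay, with a stated time of 72 h; a higher number here means a weaker inhibitor, a lower number a stronger inhibitor. Compound 1, `CCCCCCCCCCCCCCNc1nc(SCc2ccc(C(F)(F)F)cc2)nc2ccccc12`, carries a tetradecyl chain on the nitrogen attached to the shared core. For compound 1 the value in this assay is a limit of the assay, > 50000 nM, so no number is known for it. Compound 2, `FC(F)(F)c1ccc(CSc2nc(Nc3cccc(C(F)(F)F)c3)c3ccccc3n2)cc1`, places a 3-(trifluoromethyl)phenyl group on that same nitrogen, and in this assay compound 2 gives 15300 nM. That is the only numerical result shown; the other is the limit just described, (the limit of > 50000 nM in this assay, at which 1 of the 2 values shown sits), and no step between the measured compounds can be computed.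

Compound 3, `COc1ccc(Nc2nc(SCc3ccc(C(F)(F)F)cc3)nc3ccccc23)c(OC)c1`, has not yet been measured in this assay. Compared with compound 2 it differs in one place: 2,4-dimethoxyphenyl in place of 3-(trifluoromethyl)phenyl on a nitrogen on an aromatic ring. With nothing on this change in the recorded data, only a modest shift is expected, and no direction can be fixed beyond the scatter.

Compound 3 is therefore expected to land near compound 2, at an estimated 12000 nM in this assay, within 4000 nM to 40000 nM. The estimated step from compound 2 to compound 3 is a 1.3-fold lower number from compound 2 to compound 3 (0.11 log units; within the scatter).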

Compound 3, half-maximal inhibitory concentration: > 50000 nM
Compound 3 ended at the assay's limit (the forecaster's own chance of this, stated with the estimate: 20%); at least 4.1-fold (0.61 log units) between middle value and limit.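

In this assay, going by these compounds alone, the change of 3-(trifluoromethyl)phenyl to 2,4-dimethoxyphenyl on the nitrogen gives an at least 3.2-fold higher number from compound 2 to compound 3 (0.51 log units; beyond the scatter), so this position responds to a swap of one aryl group for another, although both groups hold 10 heavy atoms and one six-membered aromatic ring of carbon only; the earlier compounds could not show this, as they compared only a tetradecyl chain with a single aryl group, and that comparison ended at a limit. For compound 3 the result, > 50000 nM, is a limit of the assay and not a number, so the step gives only a lower bound on the size of the change. Compound 2 therefore remains the only compound here with a number, and the limit now covers both an aryl group and a chain on this nitrogen: the limit of > 50000 nM in this assay, at which 2 of the 3 values shown sit.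

Any step between compound 1 and compound 3 cannot be read, and how far compound 3 lies past the limit stays unknown. The compounds shown also leave open whether a single methoxy group or a plain phenyl group on this nitrogen would stay within measurable range, and so which part of the change carries the shift.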